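From trifluoromethyl to chloro in a cell tolerance test

The source may hold more compounds than are shown below. What is called first, only, known or untested is meant among the compounds shown, and "the series" means these compounds.

- Compound 1 `FC(F)(F)c1ccc(-c2nn(-c3ccccc3)cc2CNc2ccc(Cl)cc2)cc1`: 44000 nM
- Compound 2 `Cc1ccc(NCc2cn(-c3ccccc3)nc2-c2ccc(Cl)cc2)cc1`: > 100000 nM (a limit of the assay)
- Compound 3 `FC(F)(F)c1ccc(NCc2cn(-c3ccccc3)nc2-c2ccc(Cl)cc2)cc1`: 31000 nM

These values come from an ADME assay on MDBK cells (Bos taurus) for cytotoxicity, read by MTT assay, with a stated time of 72 h; a higher number here means that more compound is tolerated, a lower number that less compound is tolerated. Compound 1 (44000 nM) carries the chloro and trifluoromethyl groups swapped relative to compound 3 (31000 nM), and the two lie within the scatter of each other. Compound 4 `Clc1ccc(NCc2cn(-c3ccccc3)nc2-c2ccc(Cl)cc2)cc1` differs from compound 3 by one group: chloro in place of trifluoromethyl on an aromatic carbon. Among the measured compounds shown here, the one measured step at this place is an at least 3.2-fold lower number from compound 2 to compound 3 (0.50 log units; beyond the scatter), with trifluoromethyl in place of methyl. That step starts from a limit. The swapped pair suggests little change here, so the expected step is small and within the scatter: a 1.3-fold higher number from compound 3 to compound 4 (0.11 log units; within the scatter). Compound 4 is estimated at 40000 nM, with an expected range of 18000 nM to 90000 nM.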

Compound 4, half-maximal cytotoxic concentration: > 100000 nM
Compound 4: no number, only a limit; the forecaster's own chance of this, stated with the estimate: 15%; at least 2.5-fold (0.39 log units) between middle value and limit.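

In this assay, chloro in place of trifluoromethyl at this place is not a neutral change, giving an at least 3.2-fold higher number from compound 3 to compound 4 (0.50 log units; beyond the scatter). The same replacement on the other outer ring gives an at least 2.2-fold higher number from compound 1 to compound 4 (0.35 log units; beyond the scatter), so among these compounds, each trifluoromethyl compound has a lower number than compound 4, whichever ring carries the group. Methyl and chloro cannot be ranked, as the step between compound 2 and compound 4 cannot be read, both being limits: the limit of > 100000 nM in this assay, at which 2 of the 4 values shown sit.

As far as these compounds go, how an amine or a carboxylic acid at this place would fare remains open.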